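Thienopyrimidine series: from a thiazole to a methoxyphenyl

The source may report more compounds than this note shows. Statements on the series, on what has been measured and on what is new or still open speak of the compounds shown alone.

Of the compounds shown here, three sharing one core have been measured in a functional assay on CHO-K1 cells for antagonist activity at adenosine receptor A1 (Homo sapiens), read by a beta-galactosidase reporter and cAMP accumulation, with stated times of 15 min and 6 h; a higher number here means a weaker inhibitor, a lower number a stronger inhibitor. Compound 1 `Cc1ccc(-c2nc(N)c3cc(Cc4ccccc4)sc3n2)o1` gives 298 nM, compound 2 `Nc1nc(-c2cnco2)nc2sc(Cc3ccccc3)cc12` gives 106 nM, and compound 3 `Cc1csc(-c2nc(N)c3cc(Cc4ccccc4)sc3n2)n1` gives 1490 nM. Compound 3 therefore stands highest of the three: one step up to it is a 5.0-fold higher number from compound 1 to compound 3 (0.70 log units; beyond the scatter), and the other is a 14-fold higher number from compound 2 to compound 3 (1.15 log units; beyond the scatter). The move from compound 1 to compound 2 was a 2.8-fold lower number from compound 1 to compound 2 (0.45 log units; beyond the scatter).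

Compound 4 `COc1cccc(-c2nc(N)c3cc(Cc4ccccc4)sc3n2)c1` differs from compound 3 in one place: 3-methoxyphenyl in place of 4-methyl-1,3-thiazol-2-yl on an aromatic carbon. Among the compounds with values here, the steps that bear on this are those where the group at the same position was exchanged, which moved this assay by modest to large amounts. Within the data shown here, two of the three known groups sit well below compound 3, so a return toward lower numbers is expected, though the six-membered ring has no direct precedent here.

Compound 4 is therefore expected to give 250 nM, between 50 nM and 1200 nM, a step of a 6.0-fold lower number from compound 3 to compound 4 (0.78 log units; beyond the scatter) that is estimated rather than known.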

Compound 4, inhibition constant: 266 nM
Beside the measured number, compound 4's estimate is 1.1-fold (0.03 log units) below it, and the stated range covers the measured number.
By their numbers in this assay, from the lowest: compound 2; then compounds 4 and 1 (each within the scatter of the next); then compound 3.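

In this assay, within the data shown here, the position between two ring nitrogen atoms accepts a six-membered aromatic ring of carbon only, which the earlier compounds, all carrying five-membered aromatic rings with hetero atoms, did not show: replacing 4-methyl-1,3-thiazol-2-yl with 3-methoxyphenyl gave a 5.6-fold lower number from compound 3 to compound 4 (0.75 log units; beyond the scatter). The new group does not reach the level of 1,3-oxazol-5-yl, with a 2.5-fold higher number from compound 2 to compound 4 (0.40 log units; beyond the scatter), while its exchange for 5-methylfuran-2-yl gave a 1.1-fold lower number from compound 1 to compound 4 (0.05 log units; within the scatter), so those two groups cannot be told apart here. Nothing shown gives a measured reason for any of these differences.

As far as these compounds go, it remains open how a plain phenyl or a 4-methoxyphenyl would compare with compound 4, and so whether the methoxy group or its place on the ring matters. From the compounds shown here alone, how a saturated ring such as piperidine would fare at this position also remains open.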